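Substitution on the tetrazole: expectation for compound 4

The compounds below may be only part of what the source reports. "The series", "measured", "known", "first", "only" and "open" are said of these compounds alone.

In an ADME assay on S9 fraction from liver (Rattus norvegicus) for metabolic stability, read by LC-MS, using NADPH, with a stated time of 30 min (a lower number here means that less of the compound is left, a higher number that more of the compound is left), compound 1 `CCCCCCCCc1ccc(OCC(=O)Cn2cnnn2)cc1` gives 22%, the lower of the two numbers in the series. Compound 2 `CCCCCCCCc1ccc(OCC(=O)Cn2nnc(C(=O)O)n2)cc1` gives 52%. Compound 3 `CCCCCCCCc1ccc(OCC(=O)Cn2nnc(C(=O)OC)n2)cc1` gives < 5%, which is a limit of the assay and not a number.

Compound 4 `CCCCCCCCc1ccc(OCC(=O)Cn2nnnc2-c2cccc(Cl)c2)cc1` departs from compound 1 by 3-chlorophenyl in place of hydrogen on an aromatic carbon. Among the measured compounds shown here, two measured steps bear on this, and they run in opposite directions: a number 30 percentage points higher from compound 1 to compound 2 (beyond the scatter) and a number at least 17 percentage points lower from compound 1 to compound 3 (beyond the scatter). Both bring in a 2H-tetrazol-2-yl group, which compound 4 lacks, so they give no direction here. The expected step, with no change beyond the scatter, is a number 2 percentage points lower from compound 1 to compound 4 (within the scatter). Compound 4 is estimated at 20%, with an expected range from 6% to 45%.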

Compound 4, percent of the compound remaining: 41%
Compound 4: middle estimate off by 21 percentage points, on the low side; measured number inside the range.
By their numbers in this assay, from the lowest: compound 1; then compound 4; then compound 2. At a limit, below all of these: compound 3.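

In this assay, among the compounds shown here, 3-chlorophenyl in place of hydrogen on an aromatic carbon gives a number 19 percentage points higher from compound 1 to compound 4 (beyond the scatter), the first step at this position that brings in no 2H-tetrazol-2-yl group. The entering group has one six-membered aromatic ring of carbon only, no hydrogen-bond donors or acceptors and no net charge, so a higher number here does not depend on a carboxylic acid. Nothing measured here accounts for this step.

Going by these compounds, it remains open whether the chlorine or the ring carries the step. A plain phenyl or an aminophenyl at this position would separate these.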